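Replacing an acetylated amine chain with an amino alcohol

The compounds below may be only part of what the source reports. "The series", "measured", "known", "first", "only" and "open" are said of these compounds alone.

For the measured compounds named here, in an assay on HeLa cells for inhibition of sphingosine-1-phosphate transporter SPNS2 (Mus musculus), read by LC-MS, tested at 2 uM (on this read-out higher numbers stand for more inhibition at the one concentration tested (going by the name of the read-out) and lower numbers for less inhibition), compound 1 `CCCCCCCCCCc1ccc(-c2noc(C3CNC3)n2)cc1` gives 65%, while compound 2 `CCCCCCCCCCc1ccc(-c2noc(CC(CN)OC(C)=O)n2)cc1` gives 0%, the lowest of the two numbers measured so far; the step of a number 65 percentage points lower from compound 1 to compound 2 (beyond the scatter) shows how far the change of a number 65 percentage points lower from compound 1 to compound 2 (beyond the scatter) on an aromatic carbon lowered the read-out. Compound 3 `CCCCCCCCCCc1ccc(-c2noc(CC(O)CNCC)n2)cc1` differs from compound 2 in this way: a group of 6 heavy atoms (4 carbon, 1 nitrogen, 1 oxygen; no ring) in place of a group of 7 heavy atoms (4 carbon, 1 nitrogen, 2 oxygen; no ring), on a saturated chain carbon bound to an aromatic carbon. Going by the values given here, the only measured step that bears on this change is the one from compound 1 to compound 2, which was large and downward when a four-membered ring with one nitrogen gave way to a chain without ring. Compound 3 brings back a nitrogen carrying hydrogen within a chain, so a partial recovery is expected rather than none. Compound 3 is expected to give 35%, somewhere between 5% and 70%. For compound 3 the expected step is a number 35 percentage points higher from compound 2 to compound 3 (beyond the scatter).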

Compound 3, a percentage reported as inhibition, at one concentration (the size of the read-out at that concentration, not a potency): 5%
Beside the measured number, compound 3's estimate is 30 percentage points above it, and the stated range covers the measured number.
By their numbers in this assay, from the lowest: compounds 2 and 3 (each within the scatter of the next); then compound 1.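

In this assay, placing 3-(ethylamino)-2-hydroxypropyl on the shared core in place of the acetylated chain gives a number 5 percentage points higher from compound 2 to compound 3 (within the scatter), so the free hydroxy group and the ethylamino group do not bring back the inhibition seen with the ring. The other comparison gives a number 60 percentage points lower from compound 1 to compound 3 (beyond the scatter), which shows that the low reading of compound 2 is not specific to its acetyl group: both open chains shown here read far under azetidin-3-yl. No measurement available here explains this difference between the ring and the open chains.

As far as these compounds go, it remains open whether an open chain ending in a plain primary amine, with no hydroxy group, would behave like these chains. The same holds for whether a larger ring, such as pyrrolidine, would keep the inhibition given by azetidin-3-yl.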